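Ring amines on the shared core: from compound 1 to compound 3

The compounds below may be only part of what the source reports. "The series", "measured", "known", "first", "only" and "open" are said of these compounds alone.

For the measured compounds named here, compound 1 `CN(C)CCN(C)c1ccc(C#CC(C)(O)c2nccs2)cc1Nc1ncnc2[nH]ccc12` gives 484 nM in an assay for inhibition of mitogen-activated protein kinase kinase kinase 14 (Homo sapiens), read by luminescence and ADP-Glo, with a stated time of 120 min, in the presence of a further agent that is not named here (on this read-out higher numbers stand for weaker inhibition and lower numbers for stronger inhibition), the higher of the two numbers measured so far. Compound 2 `CN1CCCN(c2ccc(C#CC(C)(O)c3nccs3)cc2Nc2ncnc3[nH]ccc23)CC1` gives 60.1 nM in this assay. Compound 3 `CC(O)(C#Cc1ccc(N2CCN(S(=O)(=O)C3CC3)CC2)c(Nc2ncnc3[nH]ccc23)c1)c1nccs1` differs from compound 1 by 4-(cyclopropylsulfonyl)piperazin-1-yl in place of (2-(dimethylamino)ethyl)(methyl)amino on an aromatic carbon. Going by the values given here, the only measured step bearing on this change is an 8.1-fold lower number from compound 1 to compound 2 (0.91 log units; beyond the scatter), where a ring amine likewise replaced the same acyclic group, so a lower number is expected, though the sulfonyl-bearing ring has no precedent here and the size is uncertain. For compound 3 the expected step is a 3.2-fold lower number from compound 1 to compound 3 (0.51 log units; beyond the scatter). Compound 3 is estimated at 150 nM, within 40 nM to 600 nM.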

Compound 3, half-maximal inhibitory concentration: 16.2 nM
Beside the measured number, compound 3's estimate is 9.3-fold (0.97 log units) above it, and the stated range ends above it.
By their numbers in this assay, from the lowest: compound 3; then compound 2; then compound 1.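

In this assay, for the compounds shown here, this position, para to a 3-hydroxy-3-(1,3-thiazol-2-yl)but-1-yn-1-yl group, accepts a ring amine bearing a cyclopropylsulfonyl group, with the largest step so far (a 30-fold lower number from compound 1 to compound 3 (1.48 log units; beyond the scatter)). The same group also goes beyond the 4-methyl-1,4-diazepan-1-yl ring (a 3.7-fold lower number from compound 2 to compound 3 (0.57 log units; beyond the scatter)), so the ring amines differ among themselves at this position. No measurement at hand accounts for either step. Still open, going by these compounds, is how 4-(methylsulfonyl)piperazin-1-yl, 4-acetylpiperazin-1-yl or morpholine would read here, and so whether the sulfonyl, the cyclopropyl or the piperazine ring carries the step.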